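Swapping Nitro for Dimethylamino on Two Related Cores

A few compounds are considered here, and "the series" means these few. Any claim that something is new, unique, unknown or untested is made for them only; others in the source may bear on it.

Compound 1 `CC(=O)/C(C)=C/c1ccc([N+](=O)[O-])cc1` and compound 2 `CC(=O)/C(C)=C/c1ccc(N(C)C)cc1` share one core, while compound 3 `C/C(=C\c1ccc([N+](=O)[O-])cc1)C(=O)/C=C/c1ccc([N+](=O)[O-])cc1` and compound 4 `C/C(=C\c1ccc([N+](=O)[O-])cc1)C(=O)/C=C/c1ccc(N(C)C)cc1` share a larger one. How the core of compound 3 differs from the core of compound 1 is not broken down here.

In an ADME assay on J774.A1 cells (Mus musculus) for cytotoxicity, read by MTT assay, with a stated time of 48 h (a lower number here means that less compound is tolerated, a higher number that more compound is tolerated), compound 1 gives 70500 nM and compound 2 gives 160000 nM. The change between them is dimethylamino in place of nitro on an aromatic carbon, sitting para to a group of 6 heavy atoms, and it made the step of a 2.3-fold higher number from compound 1 to compound 2 (0.36 log units; beyond the scatter). In this assay, compound 3 gives 43000 nM; against compound 1 this lies within the scatter, against compound 2 beyond it.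

Compound 4 carries the same kind of change, (dimethylamino in place of nitro on an aromatic carbon), but here the place is para to a large group rather than to a group of 6 heavy atoms. The expected step for compound 4 is a 2.1-fold higher number from compound 3 to compound 4 (0.32 log units; beyond the scatter), because the same kind of change gave a 2.3-fold higher number from compound 1 to compound 2 (0.36 log units; beyond the scatter) on the core of compound 1. Compound 4 is therefore estimated at 90000 nM, with a likely range from 45000 nM to 180000 nM.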

Compound 4, half-maximal cytotoxic concentration: 24700 nM
Compound 4: middle estimate off by 3.6-fold (0.56 log units), on the high side, outside the stated range (below it).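

In this assay, the effect of dimethylamino in place of nitro does not carry over from the core of compound 1 to the larger core. The earlier step was a 2.3-fold higher number from compound 1 to compound 2 (0.36 log units; beyond the scatter), while the new one is a 1.7-fold lower number from compound 3 to compound 4 (0.24 log units; within the scatter), so the swap gives a clear rise on the first core but no readable change on the second. Among the compounds shown here, the gap between the two steps is larger than repeat measurements alone would be expected to produce, so the outcome of this swap depends on the core carrying it, at least for these four compounds: the same change on two cores in this assay, a 2.3-fold higher number (0.36 log units; beyond the scatter) from compound 1 to compound 2 and a 1.7-fold lower number (0.24 log units; within the scatter) from compound 3 to compound 4, 4.0-fold (0.60 log units) apart, beyond the scatter of two such steps With only one pair on each core, this does not show which part of the larger core is responsible, or why.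

The compounds shown leave open whether other groups in the same place, such as methoxy, chlorine or a primary amine, would also give different steps on the two cores. They also leave open what this swap would do on a third core.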